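The compounds below may be only part of what the source reports. "The series", "measured", "known", "first", "only" and "open" are said of these compounds alone.

Within the data shown here, compound 2 `CCN1CC[C@@]2(OC)OC(N)=C(C#N)[C@@H](c3ccc(Cl)cc3Cl)[C@@H]2C1` is one of two compounds measured in a functional assay on trachea (Cavia porcellus); on this read-out lower numbers stand for stronger inhibition and higher numbers for weaker inhibition. In this assay compound 2 gives 27100 nM. The other, compound 1 `CCCN1CC[C@@]2(OC)OC(N)=C(C#N)[C@@H](c3ccccc3)[C@@H]2C1`, gives 20700 nM in this assay, and the two values lie within the usual scatter of each other, so neither can be called the more potent. Compound 3 `CCCN1CC[C@@]2(OC)OC(N)=C(C#N)[C@@H](c3ccc(Cl)cc3Cl)[C@@H]2C1` has not yet been measured. It differs from compound 2 in one place: methyl in place of hydrogen on a saturated chain carbon, two bonds along the chain from an amine nitrogen in a ring. Among the measured compounds shown here, no pair of measured compounds isolates this change, so its size in this assay is open. Compound 1 already carries the longer chain and gives 20700 nM, while compound 2 gives 27100 nM; the closeness of these two is the only hint, and it points to a modest outcome. The step expected is a 1.2-fold lower number from compound 2 to compound 3 (0.09 log units; within the scatter), not beyond the scatter. Compound 3 is therefore expected to give about 22000 nM in this assay, with a likely range from 8000 nM to 60000 nM.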

Compound 3, half-maximal inhibitory concentration: 35500 nM
Compound 3: middle estimate off by 1.6-fold (0.21 log units), on the low side; the range from low to high includes it.
By their numbers in this assay, from the lowest: compounds 1, 2 and 3 (each within the scatter of the next).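

In this assay, the ethyl to propyl change, methyl in place of hydrogen on a saturated chain carbon, two bonds along the chain from an amine nitrogen in a ring, now has a measured size (a 1.3-fold higher number from compound 2 to compound 3 (0.12 log units; within the scatter)), so this assay does not separate the two chains when 2,4-dichlorophenyl is present. Among these compounds, the same compound also gives a first reading of 2,4-dichlorophenyl in place of phenyl on a saturated ring carbon (a 1.7-fold higher number from compound 1 to compound 3 (0.23 log units; within the scatter)), and this step too stays within the usual scatter. No supporting measurement is available to explain why these numbers lie so close together. Still open, on these data alone, is whether a longer chain such as butyl, or a benzyl group, on the amine nitrogen in the ring would give a step beyond the scatter. The same question applies to a single chlorine or a methoxy group on the phenyl ring.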